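The source may hold more compounds than are shown below. What is called first, only, known or untested is meant among the compounds shown, and "the series" means these compounds.

Compound 1 `COc1ccc2[nH]c(C(=O)N3CC(=O)N(Cc4ccccc4)[C@@H](CN4CCCCC4)C3)cc2c1` is examined in a physicochemical assay for solubility, read by spectrophotometry, in phosphate buffer, with a stated time of 2 h, at pH 7.4; a higher number here means a more soluble compound, a lower number a less soluble compound. In this assay compound 1 gives > 25000 nM, which is a limit of the assay and not a number. Where compound 1 stands is therefore told only by the limit of > 25000 nM in this assay, at which 1 of the 3 values shown sits. Compound 2 `COc1ccc2[nH]c(C(=O)N3CC(=O)N(Cc4ccccc4)[C@@H](CN4CCN(S(=O)(=O)c5ccccc5)CC4)C3)cc2c1` gives 16900 nM in this assay. Compound 3 `COc1ccc2[nH]c(C(=O)N3CC(=O)N(Cc4cccc(OC(F)F)c4)[C@@H](CN4CCC(C#N)CC4)C3)cc2c1` gives 27900 nM in this assay. Among the compounds with values here, no step between two measured compounds that differ in a single place is available here, so compound 1 is placed only by its limit beside the two numbers of compound 2 and compound 3.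

Compound 4 `COc1ccc2[nH]c(C(=O)N3CC(=O)N(Cc4ccccc4)[C@@H](N4CCc5ccccc54)C3)cc2c1` has not yet been measured in this assay. It differs from compound 1 in one place: 2,3-dihydro-1H-indol-1-yl in place of (piperidin-1-yl)methyl on a saturated ring carbon. Within the data shown here, the measured compounds offer no step of this kind, so the size of the change is open; the step is expected to point downward, toward lower solubility, by an amount beyond the scatter, namely an at least 3.1-fold lower number from compound 1 to compound 4 (0.49 log units; beyond the scatter). For compound 4 a solubility of 8000 nM is estimated, with an expected range from 2000 nM to 25000 nM.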

Compound 4, solubility: 7000 nM
Beside the measured number, compound 4's estimate is 1.1-fold (0.06 log units) above it; the measured number falls inside the stated range.
By their numbers in this assay, from the lowest: compound 4; then compounds 2 and 3 (each within the scatter of the next).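

Setting 2,3-dihydro-1H-indol-1-yl in place of (piperidin-1-yl)methyl on a saturated ring carbon, next to the ring nitrogen, gives in this assay an at least 3.5-fold lower number from compound 1 to compound 4 (0.55 log units; beyond the scatter), the first step here between two compounds that differ in one place. The two groups count the same hydrogen-bond donors and acceptors and neither carries a net charge, so these counts do not separate them. Compound 1 carries a limit of the assay and not a number, so the step gives only a lower bound on the size of the change: the limit of > 25000 nM in this assay, at which 1 of the 4 values shown sits.

The compounds shown leave open whether the step follows the aromatic ring of the entering group or the loss of the methyl link, which piperidin-1-yl set directly on this carbon or 2,3-dihydro-1H-indol-1-yl carried on a methyl link would separate. They also leave open how a morpholine or a carboxylic acid would behave at this position.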